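The source may hold more compounds than are shown below. What is called first, only, known or untested is meant among the compounds shown, and "the series" means these compounds.

Compound 3 `COc1ccc(-c2cc(=O)c3c(OC)cc(OC)cc3n2S(=O)(=O)c2ccc(Cl)cc2)cc1` is one of three compounds with a shared core that have been tested in an ADME assay on BJ cells (Homo sapiens) for antiproliferative activity, with a stated time of 72 h; a lower number here means that less compound is needed, a higher number that more compound is needed for the effect. For compound 3 the result is a limit, > 34400 nM, and not a number. Compound 1 `COc1ccc(-c2cc(=O)c3c(OC)cc(OC)cc3n2Cc2ccccc2)cc1` likewise returns only a limit in this assay, > 34400 nM. Compound 2 `COc1ccc(-c2c(Cl)c(=O)c3c(OC)cc(OC)cc3n2S(=O)(=O)c2ccc(OC)cc2)cc1`, which carries an additional chloro together with the (4-methoxyphenyl)sulfonyl group, gives 90000 nM in this assay. Going by the values given here, the single step between measured compounds that differ in one place, a step that the two limits leave unreadable from compound 1 to compound 3, cannot be read because both of its ends sit at the limit of > 34400 nM in this assay, at which 2 of the 3 values shown sit. Compound 4 `COc1ccc(-c2cc(=O)c3c(OC)cc(OC)cc3n2S(=O)(=O)c2ccc(OC)cc2)cc1` has not yet been measured; it differs from compound 3 by methoxy in place of chloro on an aromatic carbon. Among the compounds with values here, no measured step bears directly on this change, since none of the measured pairs differs by methoxy in place of chloro on an aromatic carbon, and the one step that exists is unreadable. Compound 2, the closest relative of compound 4, gives a number in the weak region. Compound 4 is therefore expected to remain weak, with a step that the limit leaves unreadable from compound 3 to compound 4 meaning no step beyond the scatter, and its estimated value in this assay is 60000 nM, ranging from 30000 nM to 150000 nM.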

Compound 4, half-maximal effective concentration: > 82700 nM
Compound 4 was reported as a limit; the forecaster's own chance of this, stated with the estimate: 55%; at least 1.3-fold (0.13 log units) between middle value and limit.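

The result for compound 4 in this assay is a limit and not a number, so none of its steps from compound 1, compound 2 or compound 3 can be read: the limit of > 82700 nM in this assay, at which 1 of the 4 values shown sits.

The compounds shown leave open whether methoxy in place of chloro on an aromatic carbon, or hydrogen in place of chloro on an aromatic carbon, shifts the read-out at all, with compound 2 the only one that gives a number.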